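A few compounds are considered here, and "the series" means these few. Any claim that something is new, unique, unknown or untested is made for them only; others in the source may bear on it.

Three ring-nucleoside analogues share one core and differ only in the five-membered aromatic group attached to it. Compound 1 `Cc1ccsc1-c1ncnc2c1ncn2C1O[C@H](CO)[C@@H](O)[C@H]1O` gives 2500 nM in a functional assay on CCRF-CEM cells (Homo sapiens) for inhibition; on this read-out higher numbers stand for weaker inhibition and lower numbers for stronger inhibition. Compound 2 `OC[C@H]1OC(n2cnc3c(-c4nccs4)ncnc32)[C@H](O)[C@@H]1O` gives 2730 nM in this assay, and compound 3 `OC[C@H]1OC(n2cnc3c(-c4ccoc4)ncnc32)[C@H](O)[C@@H]1O` gives 1650 nM. Compound 3 thus holds the lowest of the three numbers, yet its nearest neighbour is compound 1 and its furthest compound 2, and both gaps lie within the scatter, so no order among the three can be claimed. The step of a 1.7-fold lower number from compound 2 to compound 3 (0.22 log units; within the scatter) and the step of a 1.5-fold lower number from compound 1 to compound 3 (0.18 log units; within the scatter) are the two that bear on what follows.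

Compound 4 `Cc1csc(-c2ncnc3c2ncn3C2O[C@H](CO)[C@@H](O)[C@H]2O)n1` differs from compound 3 in one place: 4-methyl-1,3-thiazol-2-yl in place of furan-3-yl on an aromatic carbon. The reverse of the step from compound 2 to compound 3 describes a thiazol-2-yl group entering for furan-3-yl, and compound 1 shows a methyl on a five-membered ring in the same position. Both comparisons stayed within the scatter, so for compound 4 only a small rise in the number, if any, is expected in this assay. The expected step is a 1.5-fold higher number from compound 3 to compound 4 (0.18 log units; within the scatter), and the value for compound 4 is estimated at 2500 nM, with a range from 1200 nM to 5200 nM.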

Compound 4, half-maximal inhibitory concentration: 6000 nM
Compound 4: middle estimate off by 2.4-fold (0.38 log units), on the low side; measured number outside the range, above it.
By their numbers in this assay, from the lowest: compounds 3, 1 and 2 (each within the scatter of the next); then compound 4.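

Among compounds 1, 2 and 3, exchanging one five-membered aromatic group for another on this aromatic carbon of the shared core left all the steps within the scatter in this assay, whereas compound 4 gives the first steps beyond it, with a 3.6-fold higher number from compound 3 to compound 4 (0.56 log units; beyond the scatter) as the largest of them. The closest comparison is a 2.2-fold higher number from compound 2 to compound 4 (0.34 log units; beyond the scatter) for methyl in place of hydrogen on an aromatic carbon, so in this series a single methyl on the 1,3-thiazol-2-yl group is enough to separate two compounds, though the step remains modest. A methyl on the five-membered ring does not by itself go with the higher number, as a 2.4-fold higher number from compound 1 to compound 4 (0.38 log units; beyond the scatter) separates the 4-methyl-1,3-thiazol-2-yl group from 3-methylthiophen-2-yl, which also carries a methyl and stays within the scatter of compounds 2 and 3.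

The compounds shown leave open whether an ethyl, an amine or a carboxylic acid in place of the methyl of compound 4 would move the number further or bring it back. Nothing available here bears on why the methylated thiazole gives this result.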